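Halogen exchange on compound 3: working notes

A few compounds are considered here, and "the series" means these few. Any claim that something is new, unique, unknown or untested is made for them only; others in the source may bear on it.

Compound 1 `C#C[C@@]1(O)[C@@H](CO)O[C@@H](n2cnc3c(-c4ccc(Cl)cc4)ncnc32)[C@@H]1O`: 225000 nM
Compound 2 `C#C[C@@]1(O)[C@@H](CO)O[C@@H](n2cc(Br)c3c(N)ncnc32)[C@@H]1O`: 28 nM
Compound 3 `C#C[C@@]1(O)[C@@H](CO)O[C@@H](n2cc(Cl)c3c(Cl)ccnc32)[C@@H]1O`: 75000 nM

All three values come from a functional assay on L1210 cells (Mus musculus) for antiproliferative activity, read by cell counting, with a stated time of 48 h; on this read-out higher numbers stand for weaker inhibition and lower numbers for stronger inhibition. Compound 3 holds the middle place of the three. Its number lies below that of compound 1 and far above that of compound 2, and both gaps are beyond the usual scatter.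

The next compound to be read is compound 4 `C#C[C@@]1(O)[C@@H](CO)O[C@@H](n2cc(I)c3c(Cl)ccnc32)[C@@H]1O`, which keeps everything in compound 3 except one group: iodo in place of chloro on an aromatic carbon. In words, this is iodo in place of chloro on an aromatic carbon.

Going by the values given here, no two measured compounds differ in only one place, so the series offers no direct measure of such a change. Compound 2 at 28 nM shows that a low number is possible in this set, but it differs from compound 3 in more than one place and says nothing about this exchange alone. A small shift towards a lower number is expected in this assay, quite possibly none beyond the scatter.

The estimated change is a 1.5-fold lower number from compound 3 to compound 4 (0.18 log units; within the scatter). For compound 4 the estimated value is 50000 nM, with an expected range from 12000 nM to 150000 nM.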

Compound 4, half-maximal inhibitory concentration: 20000 nM
Beside the measured number, compound 4's estimate is 2.5-fold (0.40 log units) above it; low and high end bracket the measured number.
By their numbers in this assay, from the lowest: compound 2; then compound 4; then compound 3; then compound 1.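

Read in this assay, iodo in place of chloro on an aromatic carbon gives a 3.8-fold lower number from compound 3 to compound 4 (0.57 log units; beyond the scatter) as the first step in the series that changes only one place. The earlier compounds shown here could not show that the read-out responds to the identity of the halogen on this carbon of the five-membered aromatic ring, two ring bonds from the ring nitrogen; this step shows that it does, by a modest amount that lies beyond the scatter. No measurement available here accounts for the shift, so the step stands as an observation about this one pair of compounds.

On these data alone, a single exchange of one halogen for another sets no trend, and it remains open how a methyl group, a nitrile or a fluoro group on the same carbon would read. Also open, as far as these compounds go, is whether iodo in place of chloro gives a step of similar size when the other chloro of compound 3, on the six-membered ring, gives way to a methoxy group.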